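Fluorine on the Phenyl Ring of a Piperazine Amide

This account rests on a few compounds, and the source may have more. Where it says the series, first, only, none or still open, it means among the compounds named here.

Compound 1 `CN(CC(=O)N1CCN(c2ccccc2)CC1)C(=O)c1ccc(S(C)(=O)=O)c([N+](=O)[O-])c1` was examined in an assay on isolated protein for inhibition of thyroid hormone receptor beta (Homo sapiens), read by fluorescence polarization; on this read-out higher numbers stand for weaker inhibition and lower numbers for stronger inhibition. In this assay compound 1 gives only a limit, > 60000 nM, not a number. Compound 2 `CS(=O)(=O)c1ccc(C(=O)N2CCC(C(=O)N3CCN(c4ccc(F)cc4)CC3)CC2)cc1[N+](=O)[O-]`, which carries a fluorophenyl piperazine, likewise reaches only a limit in this assay, > 60000 nM. Both results rest at the limit of > 60000 nM in this assay, at which 2 of the 2 values shown sit. Compound 3 `CN(CC(=O)N1CCN(c2ccc(F)cc2)CC1)C(=O)c1ccc(S(C)(=O)=O)c([N+](=O)[O-])c1` differs from compound 1 in a single place: fluoro in place of hydrogen on an aromatic carbon. For the measured compounds named here, no measured step separates these compounds, so in this assay the step that the limit leaves unreadable from compound 1 to compound 3 is expected to stay within the scatter. Compound 3 is therefore estimated at 90000 nM, ranging from 30000 nM to 300000 nM, and most probably it will again be reported only as a limit.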

Compound 3, half-maximal inhibitory concentration: > 60000 nM
Compound 3: only a limit was reported (the forecaster's own chance of this, stated with the estimate: 90%); the middle value lies beyond the limit too.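

Compound 3, like compound 1, gives only a limit in this assay, so no step can be read between them: the limit of > 60000 nM in this assay, at which 3 of the 3 values shown sit.

How strongly any of these compounds inhibits, and what phenyl to 4-fluorophenyl changes, stays open.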